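This account rests on a few compounds, and the source may have more. Where it says the series, first, only, none or still open, it means among the compounds named here.

Measured in a functional assay on MCF7 cells (Homo sapiens) for antiproliferative activity, read by MTT assay, with a stated time of 48 h; a lower number here means a stronger inhibitor, a higher number a weaker inhibitor:
Compound 1 `Cc1cc2nc(-c3cn(-c4ccccc4)nc3-c3ccc(F)cc3)[nH]c2cc1C`: 27200 nM
Compound 2 `Cc1ccc2[nH]c(-c3cn(-c4ccccc4)nc3-c3ccc(Cl)cc3)nc2c1`: 8230 nM

Compound 2 holds the lower of these two numbers, and compound 1 stands above it by a gap beyond the usual scatter. Compound 3 `Cc1cc2nc(-c3cn(-c4ccccc4)nc3-c3ccc(Cl)cc3)[nH]c2cc1C` follows from compound 2 by one change, methyl in place of hydrogen on an aromatic carbon. For the measured compounds named here, no measured pair shows this change alone, so the data give no direct size for it in this assay. Going by the values given here, a small rise in the number is expected, not clearly beyond the scatter, because compound 1 at 27200 nM is the only other reading and it lies higher. The expected change is a 1.5-fold higher number from compound 2 to compound 3 (0.16 log units; within the scatter). In this assay the estimate for compound 3 is 12000 nM, with an expected range from 4000 nM to 30000 nM.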

Compound 3, half-maximal inhibitory concentration: 13000 nM
The estimate for compound 3 lay 1.1-fold (0.03 log units) below the measured number; low and high end bracket the measured number.
By their numbers in this assay, from the lowest: compounds 2 and 3 (each within the scatter of the next); then compound 1.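

In this assay, for the compounds shown here, the first direct reading of methyl in place of hydrogen on an aromatic carbon, ortho to a methyl group, is a 1.6-fold higher number from compound 2 to compound 3 (0.20 log units; within the scatter) and so the added methyl does not separate these two compounds. Going by these compounds alone, with both methyl groups held constant, chloro in place of fluoro on an aromatic carbon gives a 2.1-fold lower number from compound 1 to compound 3 (0.32 log units; beyond the scatter) and this modest step is the only single change here that goes beyond the scatter. No evidence accompanies these readings that would explain the size of either step.

The compounds shown carry only hydrogen or methyl at this position, so the effect of a methoxy group, an amine or a carboxylic acid there remains open. From the compounds shown here alone, the halogen step is read only with both methyl groups present, and whether it holds with a single methyl also stays open.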